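Methoxy for hydrogen on the aryl of compound 3

A few compounds are considered here, and "the series" means these few. Any claim that something is new, unique, unknown or untested is made for them only; others in the source may bear on it.

Compound 3 `Cc1nc(-c2ccccc2)sc1C(=O)CSc1nc(-c2ccccc2)c(C#N)c(=O)[nH]1` gives 92.1% in a functional assay on U-87MG ATCC cells for antiproliferative activity against U-87 MG (Homo sapiens), read by MTT assay, with a stated time of 48 h, tested at 5 uM (a lower number here means a stronger effect, a higher number a weaker effect of the compound at the concentration tested), the lowest of the three numbers shown, though it lies within the scatter of compound 2 `COc1ccc(-c2nc(C)c(C(=O)CSc3nc(-c4ccc(OC)cc4)c(C#N)c(=O)[nH]3)s2)cc1` at 97% and of compound 1 `COc1ccc(-c2nc(C)c(C(=O)CSc3nc(-c4ccc(Cl)cc4)c(C#N)c(=O)[nH]3)s2)cc1` at 102%. Compound 4 `COc1ccc(-c2nc(C)c(C(=O)CSc3nc(-c4ccccc4)c(C#N)c(=O)[nH]3)s2)cc1` differs from compound 3 by methoxy in place of hydrogen on an aromatic carbon. For the measured compounds named here, no measured step makes exactly this change; the nearest is a number 5 percentage points lower from compound 1 to compound 2 (within the scatter), which concerns methoxy on the other aromatic ring and stays within the scatter. All three numbers sit close to one another, so no step beyond the scatter is expected here, with a number 2.9 percentage points higher from compound 3 to compound 4 (within the scatter). Compound 4 is therefore expected to give about 95%, within the range 84% to 106%.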

Compound 4, a percentage reported as activity, at one concentration (the size of the read-out at that concentration, not a potency): 99%
The estimate for compound 4 lay 4 percentage points below the measured number, within the range that was stated.
By their numbers in this assay, from the lowest: compounds 3, 2, 4 and 1 (each within the scatter of the next).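

In this assay, for the compounds shown here, the change from phenyl to 4-methoxyphenyl gives a number 6.9 percentage points higher from compound 3 to compound 4 (within the scatter), the first reading of methoxy on this ring, and it leaves the read-out within the scatter. On the other aromatic ring, hydrogen in place of methoxy gives a number 2 percentage points higher from compound 2 to compound 4 (within the scatter) and hydrogen in place of chloro gives a number 3 percentage points lower from compound 1 to compound 4 (within the scatter), so these three substituents cannot be told apart there. No evidence bears on these results. As far as these compounds go, it remains open whether an amine or a carboxylic acid on either ring, or a longer chain in place of methoxy, would move the number beyond the scatter.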